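This account rests on a few compounds, and the source may have more. Where it says the series, first, only, none or still open, it means among the compounds named here.

Three compounds of the series have so far been run in an ADME assay (liver, Mus musculus) for metabolic stability, read by LC-MS, using microsomes, tested at 1 uM; a lower number here means that the compound disappears faster, a higher number that the compound lasts longer. Compound 2 `C/C(=N/c1ccnc2cc(Cl)ccc12)NCCCN1CCCCC1` gives 0.417 h, and compound 3 `CC(C)/C(=N/c1ccnc2cc(Cl)ccc12)NCCCN1CCCCC1` gives 0.717 h. Compound 1 `C/C(=N/c1ccnc2cc(Cl)ccc12)NC1CCN(Cc2ccccc2)CC1` returns only a limit of the assay, > 1 h, the limit recorded as the limit of > 1 h in this assay, at which 1 of the 3 values shown sits. The change from compound 2 to compound 3 is isopropyl in place of methyl on a carbon with a double bond to nitrogen, and it made a 1.7-fold higher number from compound 2 to compound 3 (0.24 log units; within the scatter). How the core of compound 1 differs from the core of compound 2 is not broken down here. Compound 4 `CC(C)/C(=N/c1ccnc2cc(Cl)ccc12)NC1CCN(Cc2ccccc2)CC1` carries the same change on the core of compound 1, namely (isopropyl in place of methyl on a carbon with a double bond to nitrogen), at a place described in identical words. The step that the limit leaves unreadable from compound 1 to compound 4 is expected to match the earlier 1.7-fold higher number from compound 2 to compound 3 (0.24 log units; within the scatter), and is expected to stay beyond the limit since compound 1 already sits at the limit of > 1 h in this assay, at which 1 of the 3 values shown sits. Compound 4 is estimated at 1.7 h in this assay, with an expected range from 1 h to 3 h.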

Compound 4, half-life: 0.5 h
Beside the measured number, compound 4's estimate is 3.4-fold (0.53 log units) above it; measured number outside the range, below it.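

In this assay, compound 1 gives > 1 h, which is a limit of the assay and not a number. Isopropyl in place of methyl on a carbon with a double bond to nitrogen gives an at least 2.0-fold lower number from compound 1 to compound 4 (0.30 log units; that floor lies within the scatter), and the change does not carry over unchanged from one core to the other: the same change on two cores in this assay, a 1.7-fold higher number (0.24 log units; within the scatter) from compound 2 to compound 3 and an at least 2.0-fold lower number (0.30 log units; that floor lies within the scatter) from compound 1 to compound 4, at least 3.4-fold (0.53 log units) apart, beyond the scatter of two such steps. This shows that the outcome of the change depends on the core for these two pairs, but it does not show which part of the core matters or give the full size of the step on the core of compound 1.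

The compounds shown leave open how the two cores would respond to ethyl or cyclopropyl on a carbon with a double bond to nitrogen. They also leave open whether any further core would follow compound 1 and compound 4 or compound 2 and compound 3.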